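Trading the terminal anilino group for a phenyl ring

The source may hold more compounds than are shown below. What is called first, only, known or untested is meant among the compounds shown, and "the series" means these compounds.

Of the compounds shown here, three sharing one core have been measured in a functional assay on MDA-MB-435 cells (Homo sapiens) for inhibition, read by sulforhodamine B assay, with a stated time of 48 h, tested at 100 uM; a lower number here means a stronger effect, a higher number a weaker effect of the compound at the concentration tested. Compound 1 `O=C(Nc1cccc(-n2cc(-c3ccncc3)c(-c3cc(O)cc(Cl)c3)n2)c1)Nc1ccc(Cl)c(C(F)(F)F)c1` gives -93%. Compound 2 `O=C(Nc1cccc(-n2cc(-c3ccncc3)c(-c3cc(O)cc(Cl)c3)n2)c1)Nc1ccc(Cl)c(Cl)c1` gives -45% in this assay, and the step of a number 48 percentage points higher from compound 1 to compound 2 (beyond the scatter) is the largest seen in this set. Compound 3 `COc1cc(Cl)cc(-c2nn(-c3cccc(NC(=O)Nc4ccc(Cl)c(Cl)c4)c3)cc2-c2ccncc2)c1` gives -33% in this assay, the highest of the three numbers, reached through the step of a number 12 percentage points higher from compound 2 to compound 3 (beyond the scatter).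

Compound 4 `COc1cc(Cl)cc(-c2nn(-c3cccc(NC(=O)c4cccc(C(F)(F)F)c4)c3)cc2-c2ccncc2)c1` differs from compound 3 in one place: 3-(trifluoromethyl)phenyl in place of (3,4-dichlorophenyl)amino on a carbonyl carbon. Of the two measured steps, only the first bears on this change, and only in part: it shows that a trifluoromethyl group on the terminal ring, as in compound 1, went with a far lower number than the chloro of compound 2. The loss of the amide-type nitrogen that sits on the carbonyl carbon in compound 3 has no measured counterpart among these compounds, so the size of the step is uncertain. On balance a downward step beyond the scatter is expected, a number 22 percentage points lower from compound 3 to compound 4 (beyond the scatter), though with wide uncertainty. Compound 4 is therefore estimated at -55%, in a range from -95% to -10%.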

Compound 4, a percentage reported as activity, at one concentration (the size of the read-out at that concentration, not a potency): 52%
Estimate against measurement, compound 4: 107 percentage points below; measured number outside the range, above it.
By their numbers in this assay, from the lowest: compound 1; then compound 2; then compound 3; then compound 4.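

At this position the change does far more than any earlier step suggested: in this assay the step of a number 85 percentage points higher from compound 3 to compound 4 (beyond the scatter) exceeds even the step of a number 48 percentage points higher from compound 1 to compound 2 (beyond the scatter) and carries the read-out across zero, since compound 3 gives -33% while compound 4 gives 52% at the same concentration. The earlier step tied a trifluoromethyl group on the terminal ring to the lower number, but here 3-(trifluoromethyl)phenyl enters on the carbonyl carbon, the amide-type nitrogen and its hydrogen-bond donor leave with the (3,4-dichlorophenyl)amino group, and the number goes up, so the trifluoromethyl result does not carry over to this change. No measurement shown here explains why this swap has such a large effect on the read-out.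

From the compounds shown here alone, the nitrogen, the two chlorine atoms and the trifluoromethyl group all change in this one step, so their separate shares remain open. A (3-(trifluoromethyl)phenyl)amino group or a 3,4-dichlorophenyl group on the same carbonyl carbon, or a methylene in place of that nitrogen, would divide the step into its parts.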